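The source may report more compounds than this note shows. Statements on the series, on what has been measured and on what is new or still open speak of the compounds shown alone.

Compound 1 `Nc1scc(CN2CCN(c3cc(Cl)cc(Cl)c3)CC2)c1C(=O)c1ccc(Cl)cc1` is the member of this series bearing a 3,5-dichlorophenyl on an amine nitrogen in a ring. Among the compounds with values here, in a functional assay on CHO cells with adenosine receptor A1 (Homo sapiens) as the target, read by cAMP accumulation and immunoassay, with a stated time of 6 min, tested at 1 uM (a higher number here means a weaker effect of the compound at the concentration tested, a lower number a stronger effect), compound 1 gives -69%, the second highest of the three numbers measured so far. Compound 3 `Nc1scc(CN2CCN(c3cccc(F)c3)CC2)c1C(=O)c1ccc(Cl)cc1` gives -86% in this assay and is the nearest neighbour of compound 1, while compound 2 `Nc1scc(CN2CCN(c3ccncc3)CC2)c1C(=O)c1ccc(Cl)cc1` gives -8.3% and lies furthest away. The steps among the three are uneven: a number 17 percentage points lower from compound 1 to compound 3 (beyond the scatter), whereas a number 60.7 percentage points higher from compound 1 to compound 2 (beyond the scatter) and a number 77.7 percentage points lower from compound 2 to compound 3 (beyond the scatter).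

Compound 4 `Nc1scc(CN2CCN(c3cc(F)cc(F)c3)CC2)c1C(=O)c1ccc(Cl)cc1` differs from compound 1 in one place: 3,5-difluorophenyl in place of 3,5-dichlorophenyl on an amine nitrogen in a ring. Within the data shown here, the step that bears on it is the one from compound 1 to compound 3, where a fluorine-bearing phenyl in place of the dichlorophenyl moved the number modestly lower; the step to compound 2, which introduces a pyridin-4-yl, is of another kind and gives no guidance here. A step in this assay from compound 1 to compound 4 that is small, toward a lower number or within the scatter, is therefore expected, a number 6 percentage points lower from compound 1 to compound 4 (within the scatter). For compound 4 the estimate in this assay is -75%, expected to fall between -92% and -55%.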

Compound 4, a percentage reported as activity, at one concentration (the size of the read-out at that concentration, not a potency): -66%
For compound 4 the middle estimate is 9 percentage points below the measured one, within the range that was stated.
By their numbers in this assay, from the lowest: compound 3; then compounds 1 and 4 (each within the scatter of the next); then compound 2.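

Working from this assay, the 3,5-difluorophenyl and the 3,5-dichlorophenyl cannot be told apart on this amine nitrogen in a ring (a number 3 percentage points higher from compound 1 to compound 4 (within the scatter)), so the exchange of chlorine for fluorine at both places on the phenyl leaves the read-out unresolved. The second fluorine does register, with fluoro in place of hydrogen on an aromatic carbon giving a modest change (a number 20 percentage points higher from compound 3 to compound 4 (beyond the scatter)), so compound 3 stands apart from compound 4 and, on the printed values, from compound 1 as well. The large gap to the pyridin-4-yl now holds for a third phenyl group (a number 57.7 percentage points lower from compound 2 to compound 4 (beyond the scatter)), while nothing at hand accounts for any of these steps.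

The compounds shown leave open whether the single-fluorine advantage of compound 3 extends to a 3-chlorophenyl or a 3-methoxyphenyl, or is confined to fluorine. They also leave open whether the large gap belongs to the ring nitrogen of pyridin-4-yl as such, which a pyridin-3-yl or pyridin-2-yl on the same amine nitrogen would help to separate from the effect of replacing a phenyl at all.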